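The compounds below may be only part of what the source reports. "The series", "measured", "known", "first", "only" and "open" are said of these compounds alone.

In a functional assay on NAMALVA cells (Homo sapiens) for cytotoxicity, read by MTT assay, with a stated time of 72 h (on this read-out lower numbers stand for stronger inhibition and higher numbers for weaker inhibition), compound 3 `COc1ccc(NC(=O)Nc2ccc(CCC(=O)NO)cc2)cc1` gives 1990 nM, the middle of the three measured numbers, since compound 2 `O=C(/C=C/c1ccc(NC(=O)Nc2ccc([N+](=O)[O-])cc2)cc1)NO` gives 580 nM and compound 1 `O=C(Nc1ccc(C(=O)NO)cc1)Nc1ccc([N+](=O)[O-])cc1` gives 13300 nM. Compound 4 `O=C(CCc1ccc(NC(=O)Nc2ccc([N+](=O)[O-])cc2)cc1)NO` differs from compound 3 by nitro in place of methoxy on an aromatic carbon, which is nitro in place of methoxy on an aromatic carbon. For the measured compounds named here, no measured step makes this swap. Going by the values given here, the only measured step, a 23-fold lower number from compound 1 to compound 2 (1.36 log units; beyond the scatter), is large, but it is a different change, 2-(hydroxycarbamoyl)ethenyl in place of hydroxycarbamoyl, with nitro on both compounds, so it gives no size for this swap. No step beyond the scatter is therefore expected in this assay. The estimated step is a 1.3-fold lower number from compound 3 to compound 4 (0.12 log units; within the scatter). Compound 4 is estimated at 1500 nM, with an expected range from 500 nM to 4500 nM.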

Compound 4, half-maximal inhibitory concentration: 2500 nM
For compound 4 the middle estimate is 1.7-fold (0.22 log units) below the measured one; low and high end bracket the measured number.
By their numbers in this assay, from the lowest: compound 2; then compounds 3 and 4 (each within the scatter of the next); then compound 1.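

In this assay nitro in place of methoxy on this aromatic carbon, para to a large group, leaves the number within the scatter (a 1.3-fold higher number from compound 3 to compound 4 (0.10 log units; within the scatter)). With nitro on all three compounds, the group carrying the hydroxamic end matters more: 2-(hydroxycarbamoyl)ethyl in place of 2-(hydroxycarbamoyl)ethenyl gives a modest step (a 4.3-fold higher number from compound 2 to compound 4 (0.63 log units; beyond the scatter)), and 2-(hydroxycarbamoyl)ethyl in place of hydroxycarbamoyl gives another (a 5.3-fold lower number from compound 1 to compound 4 (0.73 log units; beyond the scatter)). Nothing measured here explains these steps. Open, from the compounds shown here alone, is whether an amine or a carboxylic acid on the same aromatic carbon would also stay within the scatter, and what a longer chain ending in hydroxycarbamoyl would give.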